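Chain length and ring saturation in prostaglandin-type agonists

A few compounds are considered here, and "the series" means these few. Any claim that something is new, unique, unknown or untested is made for them only; others in the source may bear on it.

Four compounds share a bicyclic core carrying a side chain that ends in an acid. Compound 1 `O=C(O)CCCC1=CC[C@@H]2[C@@H](/C=C/[C@@H](O)COc3ccccc3)[C@H](O)C[C@@H]2OC1` has a double bond in the ring and the shorter acid chain. Compound 2 `O=C(O)CCCCC1=CC[C@@H]2[C@@H](/C=C/[C@@H](O)COc3ccccc3)[C@H](O)C[C@@H]2OC1` keeps that ring but its chain is one carbon longer, a change read as carboxymethyl in place of carboxy on a saturated chain carbon, three bonds along the chain from a double-bonded ring carbon. Compound 3 `O=C(O)CC[C@@H]1CC[C@@H]2[C@@H](/C=C/[C@@H](O)COc3ccccc3)[C@H](O)C[C@@H]2OC1` has the shorter chain on a saturated ring, and compound 4 `O=C(O)CCC[C@@H]1CC[C@@H]2[C@@H](/C=C/[C@@H](O)COc3ccccc3)[C@H](O)C[C@@H]2OC1` adds one carbon to that chain, a change read as carboxymethyl in place of carboxy on a saturated chain carbon, two bonds along the chain from a saturated ring carbon. The difference between the core of compound 1 and the core of compound 3 is not broken down here.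

In a functional assay on CHO cells for agonist activity at prostaglandin E2 receptor EP3 subtype (Homo sapiens), read by fluorescence and calcium flux (a higher number here means that more compound is needed for the effect, a lower number that less compound is needed), compound 1 gives 4700 nM, while compound 2 gives 13 nM. That is a large step, a 360-fold lower number from compound 1 to compound 2 (2.56 log units; beyond the scatter). Compound 3 gives 870 nM in this assay, a stronger result than compound 1 but far weaker than compound 2.

The change from compound 3 to compound 4 is the same kind of change as that from compound 1 to compound 2, but the surroundings differ: in one case the chain sits three bonds along the chain from a double-bonded ring carbon, in the other two bonds along the chain from a saturated ring carbon. Because the earlier step was a 360-fold lower number from compound 1 to compound 2 (2.56 log units; beyond the scatter), a clear gain is expected for compound 4 as well, though the change of ring saturation makes its size uncertain. The expected step is a 29-fold lower number from compound 3 to compound 4 (1.46 log units; beyond the scatter). Compound 4 is therefore estimated at 30 nM, between 5 nM and 200 nM.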

Compound 4, half-maximal effective concentration: 2.3 nM
For compound 4 the middle estimate is 13-fold (1.12 log units) above the measured one, outside the stated range (below it).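

Lengthening the chain on the saturated core, with carboxymethyl in place of carboxy, gives in this assay a 380-fold lower number from compound 3 to compound 4 (2.58 log units; beyond the scatter), so the large gain seen on the core of compound 1 appears again on the core of compound 3. Set side by side, the two steps agree, which means that in this series the change carries from one core to the other with its size intact: the same change on two cores in this assay, a 360-fold lower number (2.56 log units; beyond the scatter) from compound 1 to compound 2 and a 380-fold lower number (2.58 log units; beyond the scatter) from compound 3 to compound 4, 1.0-fold (0.02 log units) apart, within the scatter of two such steps. Going by these compounds alone, this rests on only two pairs of compounds in a single assay, so it does not show that the same gain would appear on any other core, it does not explain why the added carbon matters so much, and it does not separate out what the double bond in the ring contributes on its own.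

The compounds shown leave open whether a still longer chain would bring a further gain or lose what has been won, since the acid chain has been compared at only two lengths on each core. They also leave open whether an amide or a tetrazole could stand in for the carboxylic acid at the end of the chain.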